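The compounds below may be only part of what the source reports. "The series", "measured", "known", "first", "only" and "open" are said of these compounds alone.

Working notes on the series. Compound 1 `O=C(Nc1cccc(-n2cc(-c3ccncc3)c(-c3cc(O)cc(Cl)c3)n2)c1)Nc1ccc(Cl)c(C(F)(F)F)c1` carries a hydroxy group on the chlorophenyl ring. In a functional assay on T47D cells (Homo sapiens) for inhibition, read by sulforhodamine B assay, with a stated time of 48 h, tested at 0.1 uM (a higher number here means a weaker effect of the compound at the concentration tested, a lower number a stronger effect), compound 1 gives 90%. Compound 2 `COc1cc(Cl)cc(-c2nn(-c3cccc(NC(=O)Nc4ccc(Cl)c(C(F)(F)F)c4)c3)cc2-c2ccncc2)c1` differs from it by methyl in place of hydrogen on an oxygen on an aromatic ring. In this assay compound 2 gives 103%. For the measured compounds named here, the single step measured so far is a number 13 percentage points higher from compound 1 to compound 2 (beyond the scatter). On the two numbers shown compound 2 stands highest, with compound 1 as its nearest neighbour.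

Compound 3 `COc1cc(Cl)cc(-c2nn(-c3cccc(NC(=O)c4cccc(C(F)(F)F)c4)c3)cc2-c2ccncc2)c1` is the next compound, not yet measured. It differs from compound 2 by 3-(trifluoromethyl)phenyl in place of (4-chloro-3-(trifluoromethyl)phenyl)amino on a carbonyl carbon. Going by the values given here, no measured step touches this part of the molecule: the one step on record concerns only the oxygen substituent on the chlorophenyl ring, so it gives no guide to exchanging the (4-chloro-3-(trifluoromethyl)phenyl)amino group for 3-(trifluoromethyl)phenyl on the carbonyl carbon. The working expectation is therefore anchored on compound 2 itself, with a step of a number 7 percentage points lower from compound 2 to compound 3 (within the scatter) expected, which lies within the scatter. Compound 3 is estimated at 96% in this assay, with a range from 76% to 110%.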

Compound 3, a percentage reported as activity, at one concentration (the size of the read-out at that concentration, not a potency): 101%
Beside the measured number, compound 3's estimate is 5 percentage points below it; the measured number falls inside the stated range.
By their numbers in this assay, from the lowest: compound 1; then compounds 3 and 2 (each within the scatter of the next).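

In this assay, for the compounds shown here, the first reading at this position, 3-(trifluoromethyl)phenyl in place of (4-chloro-3-(trifluoromethyl)phenyl)amino on the carbonyl carbon gives a number 2 percentage points lower from compound 2 to compound 3 (within the scatter), so the read-out does not separate the two groups at the single concentration tested. This exchange removes the amino nitrogen with its hydrogen-bond donor and the chlorine in one step, so the pair cannot show what either change would do alone, and with compound 2 at 103% and compound 3 at 101%, neither compound gives a clear effect against which a loss could be seen. Nothing at hand bears on the reason for this result.

Going by these compounds, it remains open whether the same exchange would give a step beyond the scatter with the hydroxy group of compound 1 in place of the methoxy group, or at a concentration where compound 2 has a clear effect. Also open, on these data alone, is how a group of another kind on the carbonyl carbon, such as a dimethylamino group or a carboxylic acid-bearing phenyl ring, would read in this assay.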